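This account rests on a few compounds, and the source may have more. Where it says the series, first, only, none or still open, it means among the compounds named here.

Working notes on the series. Compound 1 `CCCCOc1ccc(-c2c(C)[nH]c(=O)n2C2CCCCC2)cc1` gives 13900 nM in a functional assay on brain (Rattus norvegicus, strain Wistar) for inhibition; a lower number here means a stronger inhibitor, a higher number a weaker inhibitor. Compound 2 `Cc1ccc(-c2c(C)[nH]c(=O)n2C)cc1` gives 85300 nM in this assay, the higher of the two numbers; its difference from compound 1 lies beyond the scatter. Compound 3 `Cc1[nH]c(=O)n(C)c1-c1ccc(C2CCCCC2)cc1` is not yet measured; it differs from compound 2 by cyclohexyl in place of methyl on an aromatic carbon. Among the compounds with values here, no measured pair isolates this change. A moderate step toward a lower number, beyond the scatter, is expected from compound 2 to compound 3, a 3.4-fold lower number from compound 2 to compound 3 (0.53 log units; beyond the scatter). Compound 3 is estimated at 25000 nM, within 6000 nM to 80000 nM.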

Compound 3, half-maximal inhibitory concentration: 10000 nM
Estimate against measurement, compound 3: 2.5-fold (0.40 log units) above; measured number inside the range.
By their numbers in this assay, from the lowest: compounds 3 and 1 (each within the scatter of the next); then compound 2.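

In this assay, within the data shown here, cyclohexyl in place of methyl on this aromatic carbon gives an 8.5-fold lower number from compound 2 to compound 3 (0.93 log units; beyond the scatter) and provides the first reading that isolates this position. The position accepts the larger carbon-only ring, and the number falls beyond the scatter. Nothing available here explains this step.

On these data alone, what remains open is whether the ring itself matters or only the added carbon, which a hexyl chain on the same carbon would help separate. A phenyl ring or an amine at this position would test the change further.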